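Biphenyl Ketone Variant of Compound 1

The source may hold more compounds than are shown below. What is called first, only, known or untested is meant among the compounds shown, and "the series" means these compounds.

Compound 1 `COc1ccc(/C=C/c2cc(OC)cc(OC)c2/C=C/C(=O)c2ccc(Cl)c(Cl)c2)cc1` was tested in a functional assay on HepG2 cells (Homo sapiens) for antiproliferative activity, read by MTT assay, with a stated time of 48 h (a lower number here means a stronger inhibitor, a higher number a weaker inhibitor), where compound 1 gives 10.8 ug/mL. On the three numbers shown, compound 1 holds the second highest: its nearest neighbour is compound 3 `COc1ccc(/C=C/c2cc(OC)cc(OC)c2/C=C/C(=O)c2cccc(Cl)c2)cc1`, which in this assay gives 9.5 ug/mL, and the furthest is compound 2 `COc1ccc(/C=C/c2cc(OC)cc(OC)c2/C=C/C(=O)c2ccc(C(F)(F)F)cc2)cc1`, which gives 18.7 ug/mL. The step of a 1.1-fold lower number from compound 1 to compound 3 (0.06 log units; within the scatter) and the step of a 1.7-fold higher number from compound 1 to compound 2 (0.24 log units; within the scatter) both stay within the scatter, as does a 2.0-fold lower number from compound 2 to compound 3 (0.29 log units; within the scatter), so the three measured compounds cannot be told apart by these numbers. Compound 4 `COc1ccc(/C=C/c2cc(OC)cc(OC)c2/C=C/C(=O)c2ccc(-c3ccccc3)cc2)cc1` differs from compound 1 in one place: 4-phenylphenyl in place of 3,4-dichlorophenyl on a carbonyl carbon. Among the measured compounds shown here, none of the measured steps replaces the aryl group on the carbonyl carbon with 4-phenylphenyl, so they bear on this change only loosely, and every one of them was small. The author therefore expects no step beyond the scatter in this assay, in either direction. Compound 4 is estimated to give 12 ug/mL, within a range from 6 ug/mL to 25 ug/mL. This estimate is expected to mean a step of a 1.1-fold higher number from compound 1 to compound 4 (0.05 log units; within the scatter).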

Compound 4, half-maximal inhibitory concentration: 10.5 ug/mL
Estimate against measurement, compound 4: 1.1-fold (0.06 log units) above; low and high end bracket the measured number.
By their numbers in this assay, from the lowest: compounds 3, 4, 1 and 2 (each within the scatter of the next).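

In this assay, 4-phenylphenyl on the carbonyl carbon replaces 3,4-dichlorophenyl with a 1.0-fold lower number from compound 1 to compound 4 (0.01 log units; within the scatter) as the step, so a second six-membered aromatic ring and the loss of both chlorines leave the number within the scatter. Against the other two groups, the picture is the same, with a 1.1-fold higher number from compound 3 to compound 4 (0.04 log units; within the scatter) and a 1.8-fold lower number from compound 2 to compound 4 (0.25 log units; within the scatter) as the steps, so compound 4 cannot be told apart from any of the earlier compounds. Nothing given here accounts for this flat result.

On these data alone, all four compounds carry an aromatic ring of carbon only on the carbonyl carbon, so it stays open whether any group there can move the number beyond the scatter. As far as these compounds go, how a pyridine ring, or a phenyl ring bearing an amine or a carboxylic acid, would read in this assay remains unknown.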